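This account rests on a few compounds, and the source may have more. Where it says the series, first, only, none or still open, it means among the compounds named here.

Compound 1 `C[C@@]1(c2cc(NC(=O)c3cnc(OCF)cn3)ccc2F)C=C(CF)OC(N)=N1` is the more stable of the two compounds measured in an ADME assay on microsomes from liver (Homo sapiens) for metabolic stability, read by LC-MS, using NADPH, with a stated time of 30 min, tested at 0.1 uM (on this read-out lower numbers stand for a less stable compound and higher numbers for a more stable compound), where compound 1 gives 86%. Compound 2 `C[C@@]1(c2cc(NC(=O)c3ncc(OCF)nc3N)ccc2F)C=C(CF)OC(N)=N1`, in this assay, gives 67%, the step being a number 19 percentage points lower from compound 1 to compound 2 (beyond the scatter). Compound 3 `COc1cc(C#N)cnc1C(=O)Nc1ccc(F)c([C@]2(C)C=C(CF)OC(N)=N2)c1` differs from compound 1 in another place: 5-cyano-3-methoxypyridin-2-yl in place of 5-(fluoromethoxy)pyrazin-2-yl on a carbonyl carbon. Among the compounds with values here, no measured step bears directly on this change; the only step seen concerns an amino group elsewhere. Compound 3 is therefore expected to stay near compound 1, with a shift of a number 11 percentage points lower from compound 1 to compound 3 (beyond the scatter). Compound 3 is estimated at 75%, between 55% and 92%.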

Compound 3, percent of the compound remaining: 85%
Compound 3: middle estimate off by 10 percentage points, on the low side; measured number inside the range.
By their numbers in this assay, from the lowest: compound 2; then compounds 3 and 1 (each within the scatter of the next).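

The carbonyl carbon tolerates a full exchange of its aromatic group: 5-cyano-3-methoxypyridin-2-yl in place of 5-(fluoromethoxy)pyrazin-2-yl gives, in this assay, a number 1 percentage points lower from compound 1 to compound 3 (within the scatter). Against the 3-amino-5-(fluoromethoxy)pyrazin-2-yl group, the same entering group gives a number 18 percentage points higher from compound 2 to compound 3 (beyond the scatter). No evidence is available that explains either step.

The nitrile and the methoxy group enter together, so their separate contributions cannot be told apart. On these data alone, whether a trifluoromethyl group or a carboxylic acid on this ring would give a similar reading also stays open.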